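This account rests on a few compounds, and the source may have more. Where it says the series, first, only, none or still open, it means among the compounds named here.

Measured compounds in an assay (Rattus norvegicus) for inhibition of Fatty-acid amide hydrolase 1 (Homo sapiens); on this read-out higher numbers stand for weaker inhibition and lower numbers for stronger inhibition:
compound 1 `NC(=O)c1ccc(-c2cnc(C(=O)CCCCCCc3ccccc3)o2)cc1` gives 10 nM
compound 2 `N#Cc1ccc(-c2cnc(C(=O)CCCCCCc3ccccc3)o2)cc1` gives 40 nM
compound 3 `Cc1ccnc(-c2cnc(C(=O)CCCCCCc3ccccc3)o2)c1` gives 0.6 nM

Compound 3 stands lowest of the three numbers and is the strongest inhibitor in this series: its nearest neighbour is compound 1, with a 17-fold lower number from compound 1 to compound 3 (1.22 log units; beyond the scatter) reversed, and the furthest is compound 2, with a 67-fold lower number from compound 2 to compound 3 (1.82 log units; beyond the scatter) reversed. Among the compounds with values here, the one change on the shared core that stays on the phenyl ring, a 4.0-fold higher number from compound 1 to compound 2 (0.60 log units; beyond the scatter), is modest; the two swaps that bring in the 4-methylpyridin-2-yl group are both large.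

Compound 4 `O=C(CCCCCCc1ccccc1)c1ncc(-c2cncnc2)o1` has not been measured. Relative to compound 3 the difference is pyrimidin-5-yl in place of 4-methylpyridin-2-yl on an aromatic carbon. Within the data shown here, no measured step exchanges one six-membered heteroaryl group for another at this position; the steps seen only show that the 4-methylpyridin-2-yl group sits well below either substituted phenyl group. Compound 4 is therefore expected to lose some of the advantage of compound 3, giving a step of an 8.3-fold higher number from compound 3 to compound 4 (0.92 log units; beyond the scatter), while staying nearer compound 3 than compound 2. The estimate for compound 4 is 5 nM, with a range from 1 nM to 30 nM.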

Compound 4, inhibition constant: 22 nM
For compound 4 the middle estimate is 4.4-fold (0.64 log units) below the measured one; the range from low to high includes it.
By their numbers in this assay, from the lowest: compound 3; then compound 1; then compounds 4 and 2 (each within the scatter of the next).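

In this assay one six-membered heteroaryl group cannot simply stand in for another at this position (a 37-fold higher number from compound 3 to compound 4 (1.56 log units; beyond the scatter)), so a ring nitrogen on the group attached here does not by itself give the low number of compound 3. The pyrimidin-5-yl group shows no clear separation from the 4-cyanophenyl group (a 1.8-fold lower number from compound 2 to compound 4 (0.26 log units; within the scatter)) and falls modestly short of the 4-carbamoylphenyl group (a 2.2-fold higher number from compound 1 to compound 4 (0.34 log units; beyond the scatter)), which leaves the 4-methylpyridin-2-yl group alone at the low end of these four compounds. No available measurement bears on the reason for this gap.

Open, as far as these compounds go, is whether the low number of compound 3 follows the methyl group or the pyridin-2-yl ring, which a plain pyridin-2-yl group would separate. Also open, from the compounds shown here alone, is how a pyrimidin-5-yl group carrying a methyl group or an amine would read.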